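Inverting one chain stereocentre in the series

The source may report more compounds than this note shows. Statements on the series, on what has been measured and on what is new or still open speak of the compounds shown alone.

Compound 1 `CCCC[C@@](C)(OC)[C@@H](O)/C=C/C1[C@H](O)CC(=O)[C@@H]1CCCCCCC(=O)OC` is read in a functional assay on the whole organism (Cricetulus griseus) with Cricetinae gen. sp. as the target (on this read-out higher numbers stand for an effect only at larger amounts of compound and lower numbers for an effect already at smaller amounts), where compound 1 gives > 2.5 mg/kg, a limit of the assay and not a number. Compound 3 `CCCC[C@@](C)(OC)[C@@H](O)/C=C/C1[C@H](O)CC(=O)[C@@H]1C/C=C\CCCC(=O)OC` gives > 1 mg/kg in this assay, again only a limit. Compound 2 `CCCC[C@](C)(OC)[C@H](O)/C=C/C1[C@H](O)CC(=O)[C@@H]1C/C=C\CCCC(=O)OC` gives > 1 mg/kg in this assay, also a limit. Compound 1 therefore stands at a limit, and the two further values shown are limits as well, so no ordering among the three can be read. Compound 4 `CCCC[C@@](C)(OC)[C@H](O)/C=C/C1[C@H](O)CC(=O)[C@@H]1CCCCCCC(=O)OC` differs from compound 1 in a single place: the two compounds have the same atoms and bonds; at least one stereo element is drawn with a configuration in one of them and without one in the other: 1 of 6 stereo elements differ; a stereocentre at a saturated chain carbon is drawn S in compound 1 and R in compound 4.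

Within the data shown here, two measured steps touch this region. The step that the two limits leave unreadable from compound 1 to compound 3 puts 5-(methoxycarbonyl)pent-1-en-1-yl in place of 5-(methoxycarbonyl)pentyl on a saturated chain carbon bound to a saturated ring carbon, and the step that the two limits leave unreadable from compound 2 to compound 3 inverts two chain stereocentres at once. Neither step has a readable size because the limit of > 1 mg/kg in this assay, at which 2 of the 3 values shown sit, and the limit of > 2.5 mg/kg in this assay, at which 1 of the 3 values shown sits, bound each value from one side only, and the stereochemical step is further clouded by the fact that one of compounds 2 and 3 is drawn with a defined configuration and the other without, at the place where they differ. Among the measured compounds shown here, the closest precedent for a chain-stereocentre change thus gives no direction and no size. Accordingly no step beyond scatter is expected from compound 1 to compound 4, and the step that the limit leaves unreadable from compound 1 to compound 4 is estimated as flat. Compound 4 is expected at 4 mg/kg, within 1 mg/kg to 20 mg/kg, most likely reported again as a limit.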

Compound 4, dose for half-maximal effect: > 2.5 mg/kg
Compound 4 was reported as a limit; the forecaster's own chance of this, stated with the estimate: 75%; the middle value lies beyond the limit too.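

Among these compounds, with compound 4 at > 2.5 mg/kg in this assay, a limit of the assay and not a number, and compound 1 likewise only a limit, no step between compound 1 and compound 4 can be read. The compounds shown leave open whether inverting this chain stereocentre shifts the read-out in this assay at all, and in which direction.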